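The source may report more compounds than this note shows. Statements on the series, on what has been measured and on what is new or still open speak of the compounds shown alone.

Measured so far in an ADME assay on Vero cells (Chlorocebus sabaeus) for cytotoxicity, with a stated time of 7 days; on this read-out higher numbers stand for lower toxicity in this test and lower numbers for higher toxicity in this test:

- compound 1 `COc1ccc2[nH]c(C(=O)N3CC(=O)N(Cc4ccccc4)[C@@H](COc4ccccc4)C3)cc2c1` gives a limit of the assay, > 10000 nM
- compound 2 `COc1ccc2[nH]c(C(=O)N3CC(=O)N(Cc4ccccc4)[C@@H](COCc4ccccc4)C3)cc2c1` gives a limit of the assay, > 30000 nM
- compound 3 `COc1ccc2[nH]c(C(=O)N3CC(=O)N(Cc4ccccc4)[C@@H](CN4CC5CCCCC5C4)C3)cc2c1` gives 8200 nM

For the measured compounds named here, compound 3 is the only member of the three with a number in this assay; the other two sit at limits (the limit of > 10000 nM in this assay, at which 1 of the 3 values shown sits, (the limit of > 30000 nM in this assay, at which 1 of the 3 values shown sits)). Compound 4 `COc1ccc2[nH]c(C(=O)N3CC(=O)N(Cc4ccccc4)[C@@H](CN4CC5CC5C4)C3)cc2c1` differs from compound 3 in one place: a group of 6 heavy atoms (5 carbon, 1 nitrogen; one three-membered non-aromatic ring of carbon only, one five-membered non-aromatic ring with 1 hetero atom) in place of a group of 9 heavy atoms (8 carbon, 1 nitrogen; one five-membered non-aromatic ring with 1 hetero atom, one six-membered non-aromatic ring of carbon only), on a saturated chain carbon bound to a saturated ring carbon. The two measured steps at the same saturated chain carbon both run toward the group of 9 heavy atoms: an at least 1.2-fold lower number from compound 1 to compound 3 (0.08 log units; that floor lies within the scatter) and an at least 3.6-fold lower number from compound 2 to compound 3 (0.56 log units; beyond the scatter). The step from compound 1 to compound 2, a step that the two limits leave unreadable from compound 1 to compound 2, gives no usable size. Going by the values given here, the change to compound 4 keeps a bicyclic amine at this carbon and only shrinks it, so there is no measured step that maps onto it directly; the move away from the bicyclic amine of compound 3 toward a smaller one is expected to give a step of a 1.3-fold higher number from compound 3 to compound 4 (0.13 log units; within the scatter), which lies within the scatter, with some chance of a number above compound 3 or a limit. For compound 4 in this assay the expected value is 11000 nM, with a range from 5000 nM to 25000 nM.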

Compound 4, half-maximal cytotoxic concentration: 13800 nM
Compound 4: middle estimate off by 1.3-fold (0.10 log units), on the low side; measured number inside the range.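

In this assay, for the compounds shown here, the group of 6 heavy atoms in place of the group of 9 heavy atoms, on a saturated chain carbon bound to a saturated ring carbon, gives a 1.7-fold higher number from compound 3 to compound 4 (0.23 log units; within the scatter), the first step at this carbon with a measured number at both ends, and on this evidence compound 3 and compound 4 cannot be told apart. Against the group of 8 heavy atoms, the smaller amine still gives an at least 2.1-fold lower number from compound 2 to compound 4 (0.33 log units; beyond the scatter), so in this assay the separation from compound 2 that was seen with compound 3 also holds for compound 4, though this pattern rests on those three compounds alone. Compound 1 sits at a limit of the assay, and its steps to compound 2 and compound 4 cannot be read: the limit of > 10000 nM in this assay, at which 1 of the 4 values shown sits.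

From the compounds shown here alone, what remains open is whether the separation from compound 2 would hold for an amine with a single ring, such as pyrrolidine or piperidine, for an open-chain dimethylamino group, or for a carboxylic acid at this carbon. Also open, going by these compounds, is whether these steps would keep their size if a cyclohexylmethyl group stood in place of the benzyl group shared by all four compounds.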